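Aryl versus alkyl amides: solubility on a shared core

The source may hold more compounds than are shown below. What is called first, only, known or untested is meant among the compounds shown, and "the series" means these compounds.

Measured in a physicochemical assay for solubility, read by HPLC; a lower number here means a less soluble compound, a higher number a more soluble compound:
compound 1 `O=C(c1ccc(Cl)cc1)N1CCN(c2nc(=O)c3cc(C(F)(F)F)cc([N+](=O)[O-])c3s2)CC1`: 5.19 ug/mL
compound 2 `CCC(C)C(=O)N1CCN(c2nc(=O)c3cc(C(F)(F)F)cc([N+](=O)[O-])c3s2)CC1`: 104 ug/mL
compound 3 `O=C(c1ccc(F)cc1)N1CCN(c2nc(=O)c3cc(C(F)(F)F)cc([N+](=O)[O-])c3s2)CC1`: 1.69 ug/mL

Compound 3 stands lowest of the three in this assay; its nearest neighbour is reached by a 3.1-fold lower number from compound 1 to compound 3 (0.49 log units; beyond the scatter), its furthest by a 62-fold lower number from compound 2 to compound 3 (1.79 log units; beyond the scatter). Compound 4 `O=C(C1CCC1)N1CCN(c2nc(=O)c3cc(C(F)(F)F)cc([N+](=O)[O-])c3s2)CC1` is not yet measured; it differs from compound 3 by cyclobutyl in place of 4-fluorophenyl on a carbonyl carbon. The step that bears on it is the aryl-to-alkyl exchange at the same carbonyl carbon, a 20-fold higher number from compound 1 to compound 2 (1.30 log units; beyond the scatter); the reverse direction, a 62-fold lower number from compound 2 to compound 3 (1.79 log units; beyond the scatter), was of like size. A large upward step is therefore expected for compound 4 in this assay, a 30-fold higher number from compound 3 to compound 4 (1.47 log units; beyond the scatter). Compound 4 is estimated at 50 ug/mL, with a range of 15 ug/mL to 160 ug/mL.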

Compound 4, solubility: 39.3 ug/mL
The estimate for compound 4 lay 1.3-fold (0.10 log units) above the measured number; measured number inside the range.
By their numbers in this assay, from the lowest: compound 3; then compound 1; then compound 4; then compound 2.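

In this assay a ring-bearing alkyl group on this carbonyl carbon also stands clear of both aryl amides, with a 23-fold higher number from compound 3 to compound 4 (1.37 log units; beyond the scatter) and a 7.6-fold higher number from compound 1 to compound 4 (0.88 log units; beyond the scatter), so the rise on leaving the aryl groups is not peculiar to sec-butyl. The two alkyl amides are not interchangeable either, with a 2.6-fold lower number from compound 2 to compound 4 (0.42 log units; beyond the scatter). Nothing available gives a cause for these steps. Still open, as far as these compounds go, is how a longer chain would compare at this carbonyl carbon. Also open, from the compounds shown here alone, is whether an amine or a carboxylic acid on the alkyl group would move the number further.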